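This account rests on a few compounds, and the source may have more. Where it says the series, first, only, none or still open, it means among the compounds named here.

Measured so far in a functional assay on WM 266-4 cells (Homo sapiens) for inhibition, read by MTT assay, with a stated time of 24 h; on this read-out higher numbers stand for weaker inhibition of growth and lower numbers for stronger inhibition of growth: compound 1 `COc1ccc(C2=NN(C(=O)c3ccc4c(c3)OCCO4)C(c3ccccc3)C2)cc1` gives 2370 nM; compound 2 `COc1ccc(C2=NN(C(=O)c3ccc4c(c3)OCCO4)C(c3ccc(OC)cc3)C2)cc1` gives 9890 nM.

Among the measured compounds shown here, compound 2 holds the highest of the two numbers, the only step within the set being a 4.2-fold higher number from compound 1 to compound 2 (0.62 log units; beyond the scatter). Compound 3 `COc1ccc(C2=NN(C(=O)c3ccc4c(c3)OCCO4)C(c3ccccc3F)C2)cc1` carries the change (2-fluorophenyl in place of 4-methoxyphenyl on a saturated ring carbon). For the measured compounds named here, this step is not itself covered by a measured pair; the one measured step shows that removing the methoxy from that ring moves the number down by a modest margin. Compound 3 is therefore expected to give a lower number, roughly a 3.3-fold lower number from compound 2 to compound 3 (0.52 log units; beyond the scatter), near compound 1. The estimate for compound 3 is 3000 nM, with a range of 1000 nM to 9000 nM.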

Compound 3, concentration for 50% growth inhibition: 3470 nM
Compound 3: middle estimate off by 1.2-fold (0.06 log units), on the low side; low and high end bracket the measured number.
By their numbers in this assay, from the lowest: compounds 1 and 3 (each within the scatter of the next); then compound 2.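

In this assay, 2-fluorophenyl in place of 4-methoxyphenyl on the saturated ring carbon gives a 2.9-fold lower number from compound 2 to compound 3 (0.45 log units; beyond the scatter) and shows that this position tolerates a substituent on the phenyl ring other than 4-methoxy. Fluoro in place of hydrogen on the aromatic carbon gives a 1.5-fold higher number from compound 1 to compound 3 (0.17 log units; within the scatter) and leaves 2-fluorophenyl and unsubstituted phenyl at this position indistinguishable here. No supporting measurement bears on either step.
Going by these compounds, whether the higher number of compound 2 follows from the methoxy group itself or from its ring position remains open. A 2-methoxyphenyl or 4-fluorophenyl group at this carbon would address that question.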